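The source may hold more compounds than are shown below. What is called first, only, known or untested is meant among the compounds shown, and "the series" means these compounds.

Compound 1 `CC(=O)N1N=C(Nc2nc3ccc(C)cc3s2)CC1c1ccccc1`: 106 umol/kg
Compound 2 `CC(=O)N1N=C(Nc2nc3ccc(Cl)cc3s2)CC1c1ccccc1`: 161 umol/kg

Both compounds were tested in a functional assay on the whole organism (Hindlimb, strain albino) with Mus musculus as the target, in the maximal electroshock model, with a stated time of 0.5 h; on this read-out higher numbers stand for an effect only at larger amounts of compound and lower numbers for an effect already at smaller amounts. Compound 1 gives 106 umol/kg and compound 2 gives 161 umol/kg. Of these two numbers compound 2 stands highest, but the step of a 1.5-fold higher number from compound 1 to compound 2 (0.18 log units; within the scatter) lies within the scatter, so the two compounds cannot be told apart on this read-out.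

Compound 3 `CC(=O)N1N=C(Nc2nc3ccc(Cl)cc3s2)CC1c1ccc(Cl)cc1` has not yet been measured. It differs from compound 2 in one place: chloro in place of hydrogen on an aromatic carbon. For the measured compounds named here, the only measured step on record, the exchange from compound 1 to compound 2, concerns the other aromatic ring and swaps one group for another, so it bears on the new change only loosely; it was a 1.5-fold higher number from compound 1 to compound 2 (0.18 log units; within the scatter), within the scatter. Going by the values given here, no measured step shows a chloro entering where hydrogen sat. With so little to go on, no step beyond the scatter is expected, in either direction. For compound 3 the expected step is a 1.0-fold lower number from compound 2 to compound 3 (0.00 log units; within the scatter), and the estimated value in this assay is 160 umol/kg, within a range from 80 umol/kg to 320 umol/kg.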

Compound 3, dose for half-maximal effect: 79.5 umol/kg
The estimate for compound 3 lay 2.0-fold (0.30 log units) above the measured number; the whole stated range lies above it.
By their numbers in this assay, from the lowest: compounds 3, 1 and 2 (each within the scatter of the next, the first and the last beyond it).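

Placing a chloro on the phenyl ring, turning phenyl into 4-chlorophenyl, gives a 2.0-fold lower number from compound 2 to compound 3 (0.31 log units; beyond the scatter) in this assay, a modest step but the only one in this small set that passes beyond the scatter. The earlier exchange of methyl for chloro on the other aromatic ring gave a 1.5-fold higher number from compound 1 to compound 2 (0.18 log units; within the scatter) and so showed no readable change, whereas this phenyl ring, the same in compound 1 and compound 2, turns out to be a place where one added heavy atom can shift the dose needed towards smaller amounts. No measurement in hand accounts for the size or direction of this step.

The compounds shown leave open whether this shift belongs to chloro itself or would also come with another group at the same place, such as a fluoro, a methoxy, an amine or a carboxylic acid. They also leave open whether the 4-chlorophenyl change would act in the same way alongside the methyl of compound 1, since it has been read only alongside the chloro of compound 2.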